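Heteroaryl Ring in Place of the Acid on the Pyrazole

The compounds below may be only part of what the source reports. "The series", "measured", "known", "first", "only" and "open" are said of these compounds alone.

Compound 1, `NC(=O)c1nn([C@@H]2O[C@H](CO)[C@@H](O)[C@H]2O)cc1I`, gives > 300000 nM in a functional assay on ACHN cells (feces, Homo sapiens); on this read-out lower numbers stand for stronger inhibition and higher numbers for weaker inhibition; this is a limit of the assay.
Compound 2, `C#Cc1cn([C@@H]2O[C@H](CO)[C@@H](O)[C@H]2O)nc1C(N)=O`, gives 287000 nM in this assay.
Compound 3, `O=C(O)c1nn([C@@H]2O[C@H](CO)[C@@H](O)[C@H]2O)cc1I`, gives > 300000 nM in this assay; this is a limit of the assay.

Compound 3 therefore stands at the ceiling of what this assay reports, and it shares that position with compound 1, as the limit of > 300000 nM in this assay, at which 2 of the 3 values shown sit, shows. Only compound 2 returns a number at all, and that number sits close to the same ceiling.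

Compound 4, `Cc1noc(-c2nn([C@@H]3O[C@H](CO)[C@@H](O)[C@H]3O)cc2I)n1`, is the next compound. 3-methyl-1,2,4-oxadiazol-5-yl in place of carboxy on an aromatic carbon

Two measured steps exist. The step of an at least 1.0-fold lower number from compound 1 to compound 2 (0.01 log units; that floor lies within the scatter) is within the scatter. The step that the two limits leave unreadable from compound 1 to compound 3 cannot be read, since both of its ends are limits. Neither step concerns the exchange of a carboxy group for a 3-methyl-1,2,4-oxadiazol-5-yl group, so nothing measured speaks directly to the change from compound 3 to compound 4. With every value near or at the limit, the expected step is a number no higher from compound 3 to compound 4 (the limit leaves the size open), that is, none beyond the scatter. Compound 4 is accordingly expected to give 300000 nM, with a range from 100000 nM to 1000000 nM, and most likely a limit rather than a number.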

Compound 4, half-maximal inhibitory concentration: 6200 nM
Compound 4: the middle estimate sits 48-fold (1.68 log units) above what was measured, outside the stated range (below it).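

Among the compounds shown here, the aromatic carbon next to the ring atom that bears an iodo group is the first place where a change clearly moves a compound off the ceiling of this assay: 3-methyl-1,2,4-oxadiazol-5-yl in place of carboxy gives an at least 48-fold lower number from compound 3 to compound 4 (1.68 log units; beyond the scatter). The same ring in place of carbamoyl gives an at least 48-fold lower number from compound 1 to compound 4 (1.68 log units; beyond the scatter), so the gain appears against both earlier groups at this carbon, whereas the earlier exchange of iodo for ethynyl stayed within the scatter. Both new steps are floors rather than full sizes, and the step between the two compounds at the limit cannot be read: the limit of > 300000 nM in this assay, at which 2 of the 4 values shown sit.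

As far as these compounds go, what stays open is whether the gain belongs to this particular ring or would also come with a methyl ester, a tetrazole or an isomeric oxadiazole at the same carbon, and whether the methyl on the ring could give way to an amine or a longer chain. Also open is how far the gain depends on the iodo group, since the compounds shown do not pair this ring with ethynyl or with a plain hydrogen on the neighbouring ring atom.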